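Clearance notes: from compound 1 to compound 3

The compounds below may be only part of what the source reports. "The series", "measured", "known", "first", "only" and "open" are said of these compounds alone.

Measured in an in vitro ADME assay on microsomes from Gut (Homo sapiens) for metabolic stability, in the presence of a further agent that is not named here (a lower number here means slower removal, a higher number faster removal of the compound), so far:
- compound 1 `CC(C)(CO)CNC(=O)c1cc2cc(C#N)ccc2n1Cc1cccc(OC(F)(F)F)c1` gives 136 mL.min-1.g-1
- compound 2 `CCOc1ccc(OC(F)(F)F)cc1Cn1c(C(=O)NCC(C)(C)CO)cc2cc(C#N)ccc21` gives 103 mL.min-1.g-1

Within the data shown here, compound 1 has only one measured neighbour, and the step (a 1.3-fold lower number from compound 1 to compound 2 (0.12 log units; within the scatter)) does not separate the two. Compound 3 `N#Cc1ccc2c(c1)cc(C(=O)NCCC(O)(C(F)(F)F)C(F)(F)F)n2Cc1cccc(OC(F)(F)F)c1` differs from compound 1 in one place (3,3,3-trifluoro-2-hydroxy-2-(trifluoromethyl)propyl in place of 1-(hydroxymethyl)-1-methylethyl on a saturated chain carbon bound to an amide-type nitrogen). Among the measured compounds shown here, that single measured step is an ethoxy in place of hydrogen on an aromatic carbon, so no measured step covers this chain change and the data give no direction for it. The expected step is therefore none beyond the scatter (a 1.2-fold lower number from compound 1 to compound 3 (0.09 log units; within the scatter)), with wide uncertainty. For compound 3 the estimated value is 110 mL.min-1.g-1 (expected range 45 mL.min-1.g-1 to 250 mL.min-1.g-1).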

Compound 3, intrinsic clearance in microsomes: < 6 mL.min-1.g-1
Compound 3: only a limit was reported; the forecaster's own chance of this, stated with the estimate: 5%; at least 18-fold (1.26 log units) between middle value and limit.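

In this assay, among these compounds, the saturated chain carbon bound to an amide-type nitrogen is the first place where a single change moves the read-out beyond the scatter, giving an at least 22-fold lower number from compound 1 to compound 3 (1.35 log units; beyond the scatter). The ethoxy change on the aromatic carbon gave only a 1.3-fold lower number from compound 1 to compound 2 (0.12 log units; within the scatter). Compound 3 is reported only as a limit of the assay, so its step is a minimum: the limit of < 6 mL.min-1.g-1 in this assay, at which 1 of the 3 values shown sits.

From the compounds shown here alone, whether the six fluorine atoms carry this step stays open, as a 2-hydroxy-2-methylpropyl group would test directly. An amine or a carboxylic acid at this place also remains untested among the compounds shown.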